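The compounds below may be only part of what the source reports. "The series", "measured", "known", "first", "only" and "open" are said of these compounds alone.

The measured compounds and their values in a functional assay on MDA-MB-231 cells (Homo sapiens) for cytotoxicity, read by MTT assay, with a stated time of 48 h (a higher number here means a weaker inhibitor, a lower number a stronger inhibitor), are:

compound 1 `Cc1ccc(C(=O)/C=C/c2ccc3c(c2)B(O)OC3)cc1`, 6500 nM
compound 2 `O=C(/C=C/c1ccc2c(c1)B(O)OC2)c1ccc(O)cc1`, 25600 nM
compound 3 `O=C(/C=C/c1ccc2c(c1)B(O)OC2)c1ccc([N+](=O)[O-])cc1`, 11200 nM

Compound 2 gives the highest number of the three in this assay: the step of a 3.9-fold higher number from compound 1 to compound 2 (0.60 log units; beyond the scatter) and the step of a 2.3-fold lower number from compound 2 to compound 3 (0.36 log units; beyond the scatter) both lie beyond the scatter, while the step of a 1.7-fold higher number from compound 1 to compound 3 (0.24 log units; within the scatter) does not. Compound 4 `Nc1cccc(C(=O)/C=C/c2ccc3c(c2)B(O)OC3)c1` arises from compound 2 through the change (3-aminophenyl in place of 4-hydroxyphenyl on a carbonyl carbon). Within the data shown here, two measured steps bear on this: the step of a 3.9-fold higher number from compound 1 to compound 2 (0.60 log units; beyond the scatter) and the step of a 2.3-fold lower number from compound 2 to compound 3 (0.36 log units; beyond the scatter), each replacing the hydroxy of compound 2 at the same place and each modest in size, with the hydroxy compound giving the higher number in both. Among the measured compounds shown here, compound 4 carries an amino group on a 3-aminophenyl instead, a group and a placement for which no measured step exists, so the comparison rests on the hydroxy-bearing compound 2 having given the weakest number of the three. A modest step toward a lower number is therefore expected for compound 4, of the order of a 2.1-fold lower number from compound 2 to compound 4 (0.33 log units; beyond the scatter). Compound 4 is thus estimated at 12000 nM in this assay, with a range from 5000 nM to 30000 nM.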

Compound 4, half-maximal inhibitory concentration: 3200 nM
Beside the measured number, compound 4's estimate is 3.8-fold (0.57 log units) above it, outside the stated range (below it).
By their numbers in this assay, from the lowest: compound 4; then compounds 1 and 3 (each within the scatter of the next); then compound 2.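

In this assay the 3-aminophenyl on the carbonyl carbon gives an 8.0-fold lower number from compound 2 to compound 4 (0.90 log units; beyond the scatter) and also a 2.0-fold lower number from compound 1 to compound 4 (0.31 log units; beyond the scatter) on the same scale, so this place tolerates a change that takes the number beyond the scatter on the lower side of compound 1, which had held the lowest number among compounds 1, 2 and 3. The earlier steps shown here only exchanged groups at a single placement on the phenyl ring, whereas this one shows that a change of both group and placement can move the number further down, even though the computed counts of heavy atoms, hydrogen-bond donors and hydrogen-bond acceptors are the same for 4-hydroxyphenyl and 3-aminophenyl. Nothing shown here offers a reason for either step.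

Going by these compounds, the step from compound 2 to compound 4 changes the group and its placement at once, so the share of each in the lower number stays open. A phenyl carrying the amine where compound 2 carries its hydroxy, or the hydroxy where compound 4 carries its amine, would separate the two, and whether a carboxylic acid or a dimethylamino group at either placement follows the amine is also unanswered.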